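Replacing Carboxy with (Ethylcarbamoyl)amino: An Expected Loss

The source may hold more compounds than are shown below. What is called first, only, known or untested is meant among the compounds shown, and "the series" means these compounds.

Compound 1 `O=C(COc1ccc(Oc2ccccc2)cc1)Cn1ncc2cc(C(=O)O)ccc21` is the strongest of the three measured compounds: in an assay on microsomes from brain for inhibition of Fatty-acid amide hydrolase 1 (Rattus norvegicus), read by fluorescence and HPLC, with a stated time of 45 min (on this read-out higher numbers stand for weaker inhibition and lower numbers for stronger inhibition), compound 1 gives 55 nM, its nearest neighbour being compound 3 `O=C(COc1ccc(Oc2ccccc2)cc1)Cn1ncc2cc([N+](=O)[O-])ccc21`, which gives 550 nM, and the furthest being compound 2 `COCC(=O)Nc1ccc2c(cnn2CC(=O)COc2ccc(Oc3ccccc3)cc2)c1`, which gives 6300 nM. Compound 4 `CCNC(=O)Nc1ccc2c(cnn2CC(=O)COc2ccc(Oc3ccccc3)cc2)c1` differs from compound 1 in one place: (ethylcarbamoyl)amino in place of carboxy on an aromatic carbon. The measured step that bears most directly on this change is a 110-fold higher number from compound 1 to compound 2 (2.06 log units; beyond the scatter), where carboxy likewise gave way to a group carrying a carbonyl and linked through nitrogen; the step of a 10-fold higher number from compound 1 to compound 3 (1.00 log units; beyond the scatter), where a group with no hydrogen-bond donor entered, was smaller but pointed the same way. Both steps leave the carboxy-bearing compound 1 with the lowest number, so a large rise in this assay is expected for compound 4, though the new group is not the same as that in compound 2 and the size remains uncertain. Compound 4 is therefore estimated at 3000 nM, with a range from 800 nM to 12000 nM, which means an expected step of a 55-fold higher number from compound 1 to compound 4 (1.74 log units; beyond the scatter).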

Compound 4, half-maximal inhibitory concentration: 1600 nM
For compound 4 the middle estimate is 1.9-fold (0.27 log units) above the measured one; measured number inside the range.
By their numbers in this assay, from the lowest: compound 1; then compound 3; then compound 4; then compound 2.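

In this assay the (ethylcarbamoyl)amino group does not make up for the loss of carboxy on this aromatic carbon: the change gives a 29-fold higher number from compound 1 to compound 4 (1.46 log units; beyond the scatter) and compound 1 keeps the lowest number of the four. The new group also falls behind nitro at the same place, with a 2.9-fold higher number from compound 3 to compound 4 (0.46 log units; beyond the scatter) as the step between them. The carbonyl-bearing groups linked through nitrogen are not interchangeable here either: ethylamino in place of methoxymethyl on the carbonyl carbon gives a 3.9-fold lower number from compound 2 to compound 4 (0.60 log units; beyond the scatter) and so shows that the end of this group affects the number. Nothing shown explains these differences. Open questions are whether a propyl chain in place of ethyl lowers the number further, and whether a tetrazole or a primary amine on this aromatic carbon comes close to compound 1.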